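This account rests on a few compounds, and the source may have more. Where it says the series, first, only, none or still open, it means among the compounds named here.

Measured so far in a functional assay on cells (Cancer cell lines, Homo sapiens) for cytotoxicity, with a stated time of 48 h; a higher number here means a weaker inhibitor of growth, a lower number a stronger inhibitor of growth:

Compound 1, `COc1c(/C=C2/C(=O)Nc3ccccc32)c2ccccc2n1-c1ccccc1`, gives 4470 nM.
Compound 2, `COc1c(/C=C2/C(=O)Nc3ccc(Cl)cc32)c2ccccc2n1-c1ccccc1`, gives 13800 nM.

Compound 2 stands at the higher of the two numbers, so it is the weaker growth inhibitor of the pair, and the gap to compound 1 is beyond the scatter. Among the measured compounds shown here, the only step measured, a 3.1-fold higher number from compound 1 to compound 2 (0.49 log units; beyond the scatter), replaced a hydrogen on the aromatic carbon of the shared core with a chlorine and weakened inhibition modestly.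

Compound 3, `COc1ccc2c(c1)/C(=C\c1c(OC)n(-c3ccccc3)c3ccccc13)C(=O)N2`, differs from compound 2 in one place: methoxy in place of chloro on an aromatic carbon. Thus the chlorine at that position gives way to a methoxy group. For the measured compounds named here, no measured step exchanges chlorine for methoxy, so the single step from compound 1 to compound 2 bears on it only indirectly: it shows that this position tolerates a substituent with a modest loss of potency, but not how methoxy compares with chloro there.

Given that, compound 3 is expected to land near compound 2, with an estimated step of a 1.5-fold lower number from compound 2 to compound 3 (0.19 log units; within the scatter), most likely within the scatter. The estimate for compound 3 in this assay is 9000 nM, with a range from 3000 nM to 27000 nM.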

Compound 3, concentration for total growth inhibition: 7240 nM
The estimate for compound 3 lay 1.2-fold (0.09 log units) above the measured number; measured number inside the range.
By their numbers in this assay, from the lowest: compounds 1, 3 and 2 (each within the scatter of the next, the first and the last beyond it).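

Swapping chloro for methoxy gives a 1.9-fold lower number from compound 2 to compound 3 (0.28 log units; within the scatter), so this exchange, which brings in a hydrogen-bond acceptor, cannot be told apart from no change at all. Methoxy in place of hydrogen on the same aromatic carbon gives a 1.6-fold higher number from compound 1 to compound 3 (0.21 log units; within the scatter), so unlike chloro, methoxy shows no loss of growth inhibition that clears the scatter. The earlier pair could be read as a sign that any substituent at this position costs potency, but methoxy does not support that reading: only hydrogen and chloro are separated, and methoxy cannot be told apart from either.

As far as these compounds go, how an amine, a carboxylic acid or a longer chain such as butoxy would behave on this aromatic carbon remains open, as does whether methoxy would give the same result elsewhere on the shared core. Nothing available here explains why chloro and methoxy differ from hydrogen as they do, and three compounds in one cell-based assay give no basis for an explanation.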